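The source may hold more compounds than are shown below. What is called first, only, known or untested is meant among the compounds shown, and "the series" means these compounds.

Compound 3 `O=C(NCCO)c1c(Cn2c(=O)n(C3CC3)c3ccncc32)nc2cc(Cl)ccn12` stands at a limit in an ADME assay on HEp-2 cells (Homo sapiens) for cytotoxicity, read by CCK-8 assay, with a stated time of 6 days; on this read-out lower numbers stand for higher toxicity in this test and higher numbers for lower toxicity in this test: compound 3 gives > 100000 nM, which is a limit of the assay and not a number. Compound 2 `O=C(O)c1c(Cn2c(=O)n(C3CC3)c3ccncc32)nc2cc(Cl)ccn12` likewise stands at a limit; in this assay compound 2 gives > 100000 nM, a limit and not a number. For the measured compounds named here, compound 1 `N#Cc1c(Cn2c(=O)n(C3CC3)c3ccncc32)nc2cc(Cl)ccn12` is the only compound with a read number; in this assay compound 1 gives 22500 nM. Both steps away from compound 1 run into the limit of > 100000 nM in this assay, at which 2 of the 3 values shown sit: an at least 4.4-fold higher number from compound 1 to compound 2 (0.64 log units; beyond the scatter), and an at least 4.4-fold higher number from compound 1 to compound 3 (0.64 log units; beyond the scatter). Between the two limits the step is a step that the two limits leave unreadable from compound 2 to compound 3. Compound 4 `O=C(O)/C=C/c1c(Cn2c(=O)n(C3CC3)c3ccncc32)nc2cc(Cl)ccn12` differs from compound 3 by 2-carboxyethenyl in place of (2-hydroxyethyl)carbamoyl on an aromatic carbon. Going by the values given here, the step that bears on it is the one from compound 1 to compound 2, where a carboxy group entered and the number rose to the limit; the step from compound 1 to compound 3 went the same way. Compound 4 is therefore expected to give 100000 nM, in a range from 30000 nM to 300000 nM, most likely again as a limit. That estimate means a step of a number no higher from compound 3 to compound 4 (the limit leaves the size open) that is expected to stay within the scatter.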

Compound 4, half-maximal cytotoxic concentration: > 100000 nM
Compound 4: a limit, no number (the forecaster's own chance of this, stated with the estimate: 60%); the middle value lies on the limit itself.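

In this assay, 2-carboxyethenyl in place of cyano on this aromatic carbon gives an at least 4.4-fold higher number from compound 1 to compound 4 (0.64 log units; beyond the scatter). The change seen with carboxy in compound 2 therefore does not require the carboxy group to sit directly on the aromatic carbon, since it also appears when that group is carried on an ethenyl link in compound 4. The steps among compound 2, compound 3 and compound 4 cannot be read, and no order among these compounds can be given: the limit of > 100000 nM in this assay, at which 3 of the 4 values shown sit.

Going by these compounds, how far the true values of compound 2, compound 3 and compound 4 lie beyond that limit stays open. Also open, on these data alone, is whether a group with neither carboxy nor hydroxy, such as an aminomethyl group or a plain ethyl chain, would move the number away from that of compound 1 on this carbon.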